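The compounds below may be only part of what the source reports. "The series", "measured", "known", "first", "only" and "open" are said of these compounds alone.

Working notes on the series. In an ADME assay on K562 cells (Homo sapiens) for cytotoxicity, with a stated time of 72 h (a lower number here means a stronger inhibitor, a higher number a weaker inhibitor), compound 1 (`COc1cccc(CNc2ncnc3c2ncn3C2CCCCO2)c1`) gives 61000 nM. Compound 2 (`COc1cccc(CNc2ncnc3c2ncn3C2CCCO2)c1`) stands at > 100000 nM, which is a limit and not a number. Compound 3 (`COc1ccc(OC)c(CNc2ncnc3c2ncn3C2CCCO2)c1`) stands at > 50000 nM, which is likewise a limit. Compound 4 (`COc1cc(CNc2ncnc3c2ncn3C2CCCO2)ccc1O`) is one change away from compound 2: hydroxy in place of hydrogen on an aromatic carbon. In words, this is hydroxy in place of hydrogen on an aromatic carbon.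

Going by the values given here, two measured steps bear on this. Oxolan-2-yl in place of oxan-2-yl gives an at least 1.6-fold higher number from compound 1 to compound 2 (0.21 log units; that floor lies within the scatter), and this change lies elsewhere in the molecule. The nearer case is methoxy in place of hydrogen on an aromatic carbon, which gives a step that the two limits leave unreadable from compound 2 to compound 3. Neither step offers a readable size, so no shift beyond the scatter is expected in this assay. The expected step is an at least 1.1-fold lower number from compound 2 to compound 4 (0.04 log units; that floor lies within the scatter). Compound 4 is estimated at 90000 nM, with an expected range of 35000 nM to 200000 nM, and a report as a limit alone would not be surprising.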

Compound 4, half-maximal inhibitory concentration: > 100000 nM
Compound 4 gave a limit, no number (the forecaster's own chance of this, stated with the estimate: 65%); middle value at least 1.1-fold (0.04 log units) from the limit.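

In this assay compound 4 gives > 100000 nM, a limit and not a number. Going by these compounds alone, compound 2 also stands at a limit, so no step from compound 2 to compound 4 can be read. The compounds shown leave open whether hydroxy in place of hydrogen on an aromatic carbon shifts the number at all.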